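A few compounds are considered here, and "the series" means these few. Any claim that something is new, unique, unknown or untested is made for them only; others in the source may bear on it.

Working notes on the series.

Compound 2 `O=C(/C=C/c1cccc(O)c1)c1cc(O)c(O)c([N+](=O)[O-])c1` is the reference point here. In an assay on isolated protein for inhibition of Amine oxidase [flavin-containing] A (Homo sapiens), read by fluorescence (on this read-out lower numbers stand for stronger inhibition and higher numbers for weaker inhibition), compound 2 gives 43900 nM, the lowest of the two numbers recorded so far; its nearest neighbour is compound 1 `O=C(/C=C/c1cccs1)c1cc(O)c(O)c([N+](=O)[O-])c1`, which in this assay gives 49900 nM, and the step of a 1.1-fold lower number from compound 1 to compound 2 (0.06 log units; within the scatter) lies within the scatter, so the two are read as equivalent.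

Compound 3 `O=C(/C=C/c1ccco1)c1cc(O)c(O)c([N+](=O)[O-])c1` has not yet been measured. The change from compound 2 to compound 3 is furan-2-yl in place of 3-hydroxyphenyl on a double-bonded chain carbon bound to a double-bonded chain carbon. Among the compounds with values here, the only measured step that bears on it is the one from compound 1 to compound 2, which exchanged thiophen-2-yl for 3-hydroxyphenyl at the same place and was a 1.1-fold lower number from compound 1 to compound 2 (0.06 log units; within the scatter). Compound 3 carries furan-2-yl, a five-membered aromatic ring with one hetero atom like the thiophen-2-yl of compound 1, so the expectation for compound 3 in this assay is a step of a 1.1-fold higher number from compound 2 to compound 3 (0.03 log units; within the scatter), that is none beyond the scatter, given that the step from compound 1 to compound 2 was a 1.1-fold lower number from compound 1 to compound 2 (0.06 log units; within the scatter).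

The estimate for compound 3 in this assay is therefore 47000 nM, expected to fall within 20000 nM to 110000 nM.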

Compound 3, half-maximal inhibitory concentration: 60500 nM
Estimate against measurement, compound 3: 1.3-fold (0.11 log units) below, within the range that was stated.
By their numbers in this assay, from the lowest: compounds 2, 1 and 3 (each within the scatter of the next).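

In this assay the new data give a 1.4-fold higher number from compound 2 to compound 3 (0.14 log units; within the scatter) and a 1.2-fold higher number from compound 1 to compound 3 (0.08 log units; within the scatter) so furan-2-yl reads as equivalent to both 3-hydroxyphenyl and thiophen-2-yl on a double-bonded chain carbon bound to a double-bonded chain carbon, and all three groups now form one set within the scatter. The step from 3-hydroxyphenyl to furan-2-yl goes from a six-membered aromatic ring of carbon only to a five-membered aromatic ring, from 7 to 5 heavy atoms and from 1 hydrogen-bond donor to 0, yet none of these differences carries the number beyond the scatter, and the exchange between the two five-membered rings does not do so either. No measurement is available that would explain this flat response.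

Still open is whether any group at this place moves the number beyond the scatter, since the three compounds shown all carry a single aromatic ring there. An amine or a carboxylic acid on that ring, or a longer chain in its stead, would test this, and the compounds shown say nothing about changes elsewhere on the shared core.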